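Swapping Ethoxy for Methylsulfanyl on the Side Chain

A few compounds are considered here, and "the series" means these few. Any claim that something is new, unique, unknown or untested is made for them only; others in the source may bear on it.

In a functional assay on the whole organism (stomach) for inhibition, with Canis familiaris (Canis lupus familiaris) as the target, at a dose of 5 mg/kg by the intravenous route (a lower number here means a weaker effect, a higher number a stronger effect of the compound at the dose given), compound 1 `Cc1cn2cccc(OCc3ccccc3)c2n1` gives 70%. Within the data shown here, compound 2 `CCOCc1c(C)nc2c(OCc3ccccc3)cccn12` gives 35%, the lower of the two numbers known so far, and the one step measured, a number 35 percentage points lower from compound 1 to compound 2 (beyond the scatter), shows that adding the chain to the core cost much of the inhibition. Compound 3 `CSCc1c(C)nc2c(OCc3ccccc3)cccn12` differs from compound 2 in one place: methylsulfanyl in place of ethoxy on a saturated chain carbon bound to an aromatic carbon. Among the measured compounds shown here, no measured step exchanges one chain for another of this kind; the only step known concerns adding a chain, not altering it, so it bears only loosely on this change. Compound 3 keeps a chain of similar size at the place where compound 2, with 35%, already carries one. The step of no change at the digits printed from compound 2 to compound 3 (within the scatter) is therefore expected to stay within the scatter. For compound 3 the estimate is 35%, in the range 15% to 55%.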

Compound 3, a percentage reported as inhibition, in the whole organism at one dose (the size of the read-out at that dose, not a potency): 8%
Compound 3: the middle estimate sits 27 percentage points above what was measured, outside the stated range (below it).
By their numbers in this assay, from the lowest: compound 3; then compound 2; then compound 1.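

In this assay, among these compounds, the earlier compounds showed only that adding a chain to the core could cost inhibition, whereas exchanging ethoxy for methylsulfanyl gives a number 27 percentage points lower from compound 2 to compound 3 (beyond the scatter) and so shows that the group on this saturated chain carbon matters, not just the presence of a chain. Set against compound 1, which lacks the chain, the new chain gives a number 62 percentage points lower from compound 1 to compound 3 (beyond the scatter) and leaves little of the inhibition behind, a larger loss than a number 35 percentage points lower from compound 1 to compound 2 (beyond the scatter) for the ethoxymethyl chain. The compounds offer no measurement that explains why the two chains differ.

From the compounds shown here alone, whether a longer chain such as propoxy would give more inhibition than ethoxy at this place stays open. So does whether an amine such as dimethylamino would bring the number back towards that of compound 1.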